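The source may report more compounds than this note shows. Statements on the series, on what has been measured and on what is new or still open speak of the compounds shown alone.

Measured so far:
Compound 1, `COc1ccccc1-c1cn(-c2ccc(O)c(C(=O)Nc3cccc(C(F)(F)F)c3)c2)nn1`, 61%
Compound 2, `COc1cc(OC)cc(-c2cn(-c3ccc(O)c(C(=O)O)c3)nn2)c1`, 2%

In a functional assay on HCT-116 cells (Homo sapiens) for inhibition, read by MTT assay, with a stated time of 2 days, tested at 10 uM (on this read-out higher numbers stand for more inhibition at the one concentration tested (going by the name of the read-out) and lower numbers for less inhibition), compound 1 gives 61%. In this assay compound 2 gives 2%, the lowest of the two numbers available; its nearest neighbour is compound 1, whose number is higher by a margin beyond the usual scatter. Compounds 1 and 2 differ in more than one place, so their two values alone describe them, and no single step can be read between them.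

The step from compound 2 to compound 3 changes one place only. Compound 3, `COc1cc(OC)cc(-c2cn(-c3ccc(O)c(C(=O)Nc4cccc(C(F)(F)F)c4)c3)nn2)c1`, is not yet measured. The change is (3-(trifluoromethyl)phenyl)amino in place of hydroxy on a carbonyl carbon. Compound 3 thus carries the same (3-(trifluoromethyl)phenyl)amino on the carbonyl carbon that compound 1 carries, while keeping the rest of compound 2. Given that compound 1 gives 61% and compound 2 gives 2%, a large upward step in this assay is expected, well beyond the scatter.

Compound 3 is therefore estimated at 52%, with a range from 25% to 75%. The expected step of a number 50 percentage points higher from compound 2 to compound 3 (beyond the scatter) reflects this estimate.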

Compound 3, a percentage reported as inhibition, at one concentration (the size of the read-out at that concentration, not a potency): 62%
Estimate against measurement, compound 3: 10 percentage points below; measured number inside the range.
By their numbers in this assay, from the lowest: compound 2; then compounds 1 and 3 (each within the scatter of the next).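

In this assay the swap of hydroxy for (3-(trifluoromethyl)phenyl)amino on a carbonyl carbon gives a number 60 percentage points higher from compound 2 to compound 3 (beyond the scatter) and leaves the rest of compound 2 untouched, so this large rise can be tied to this one place, which compounds 1 and 2 alone did not allow. With that group in place, 3,5-dimethoxyphenyl instead of 2-methoxyphenyl on an aromatic carbon gives a number 1 percentage points higher from compound 1 to compound 3 (within the scatter) in this assay and this stays within the scatter, so the read-out does not separate these two groups in this setting. The data at hand offer no measurement that would explain the size of the step at the carbonyl carbon.

As far as these compounds go, it remains open whether the whole (3-(trifluoromethyl)phenyl)amino is needed, or whether a smaller group on the carbonyl carbon, such as methylamino or a methyl ester, or plain phenylamino without the trifluoromethyl, would give a similar number. From the compounds shown here alone, it is equally open whether 3,5-dimethoxyphenyl and 2-methoxyphenyl would also match when hydroxy sits on the carbonyl carbon, since only compound 2 shows that combination.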